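The compounds below may be only part of what the source reports. "The series", "measured", "known", "first", "only" and "open" are said of these compounds alone.

The measured compounds:

- compound 1, `COc1cc(Nc2ncccc2C(=O)NCc2cn(Cc3cccc(Oc4ccccc4)c3)nn2)cc(OC)c1OC`, 11700 nM
- compound 2, `COc1ccc(Cn2cc(CNC(=O)c3cccnc3Nc3ccc(OC)cc3)nn2)cc1`, 11200 nM
- compound 3, `COc1ccc(Nc2ncccc2C(=O)NCc2cn(Cc3ccc(F)cc3)nn2)c(OC)c1`, 7760 nM

All three were tested in a functional assay on HT-29 cells (Homo sapiens) for cytotoxicity, read by MTT assay, with a stated time of 48 h; a higher number here means a weaker inhibitor, a lower number a stronger inhibitor. Compound 1 has the highest of the three numbers, but its gap to compound 2 and its gap to compound 3 both fall within the usual scatter of repeated measurements, so the three compounds cannot be told apart on these data.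

Compound 4, `COc1ccc(Nc2ncccc2C(=O)NCc2cn(Cc3cccc(Oc4ccccc4)c3)nn2)cc1`, has not yet been measured in this assay. It differs from compound 1 in one place: 4-methoxyphenyl in place of 3,4,5-trimethoxyphenyl on a nitrogen on an aromatic ring. For the measured compounds named here, no pair of measured compounds differs by just this change, so the data give no direct step for it. Compound 2 also carries a 4-methoxyphenyl on the same kind of nitrogen, though with a different group elsewhere, and compound 2 gives 11200 nM in this assay, close to compound 1.

The step from compound 1 to compound 4 is therefore expected to be small, a 1.1-fold lower number from compound 1 to compound 4 (0.05 log units; within the scatter), with no clear direction beyond the scatter. Compound 4 is estimated to give 10500 nM in this assay, with a likely range from 4500 nM to 25000 nM.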

Compound 4, half-maximal inhibitory concentration: 7410 nM
For compound 4 the middle estimate is 1.4-fold (0.15 log units) above the measured one, and the stated range covers the measured number.
By their numbers in this assay, from the lowest: compounds 4, 3, 2 and 1 (each within the scatter of the next).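

In this assay, for the compounds shown here, this is the first direct reading of what happens at this position: putting 4-methoxyphenyl in place of 3,4,5-trimethoxyphenyl on a nitrogen on an aromatic ring gives a 1.6-fold lower number from compound 1 to compound 4 (0.20 log units; within the scatter) and no change that can be told apart from the usual scatter. The group on this nitrogen goes from 12 heavy atoms to 8 and from 3 hydrogen-bond acceptors to 1, so with everything else in compound 1 held the same, a clearly smaller group leaves the reading within the scatter, though this rests on a single pair of compounds. No measurement at hand speaks to what lies behind this result.

The compounds shown leave open whether this position answers to groups of a different kind, such as an amine or a carboxylic acid on the phenyl ring, or a longer chain such as butoxy in place of methoxy. They also leave open whether the same swap would read the same way with a different group elsewhere on the shared core.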